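Aryl Swaps on a Carbamate Analgesic Scaffold

The source may hold more compounds than are shown below. What is called first, only, known or untested is meant among the compounds shown, and "the series" means these compounds.

Compound 2 `NC(=O)OC(CCN1CCN(c2ccccc2)CC1)c1cccc([N+](=O)[O-])c1` was assessed in a functional assay on the whole organism for inhibition, with Mus musculus as the target, in the writhing test, with a stated time of 1 h, at a dose of 10 mg/kg by the intraperitoneal route (on this read-out higher numbers stand for more inhibition at the one dose given (going by the name of the read-out) and lower numbers for less inhibition), where compound 2 gives 100%. Within the data shown here, compound 1 `Cc1ccc(C(CCN2CCN(c3ccccc3)CC2)OC(N)=O)cc1` in this assay gives 100%, so compound 2 stands level with compound 1 at the digits reported, and together they hold the highest of the three numbers known. The step of no change at the digits printed from compound 1 to compound 2 (within the scatter), a 3-nitrophenyl in place of 4-methylphenyl on a saturated chain carbon bound to an oxygen next to a carbonyl group and a saturated chain carbon, left the read-out unchanged within the scatter. Compound 3 `NC(=O)OC(CCN1CCN(c2cccc(C(F)(F)F)c2)CC1)c1ccccc1` differs from compound 2 in more than one place. In this assay compound 3 gives 14.6%, a number far below that of compound 2.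

Compound 4 `COc1ccc(C(CCN2CCN(c3ccccc3)CC2)OC(N)=O)cc1` has not yet been measured. It differs from compound 2 as follows: 4-methoxyphenyl in place of 3-nitrophenyl on a saturated chain carbon bound to an oxygen next to a carbonyl group and a saturated chain carbon. Among the measured compounds shown here, the only measured step that bears on this change is no change at the digits printed from compound 1 to compound 2 (within the scatter), in which one aryl group replaced another at the same place and the read-out did not move beyond the scatter. On that basis compound 4 is expected to show a step of a number 8 percentage points lower from compound 2 to compound 4 (within the scatter), that is, none beyond the scatter. Compound 4 is accordingly estimated at 92%, with a range from 65% to 100%.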

Compound 4, a percentage reported as inhibition, in the whole organism at one dose (the size of the read-out at that dose, not a potency): 100%
For compound 4 the middle estimate is 8 percentage points below the measured one; measured number inside the range.
By their numbers in this assay, from the lowest: compound 3; then compounds 1, 2 and 4 (each within the scatter of the next).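

With the step of no change at the digits printed from compound 2 to compound 4 (within the scatter), a second exchange of one aryl group for another on a saturated chain carbon bound to an oxygen next to a carbonyl group and a saturated chain carbon leaves the read-out where it was, even though the 3-nitrophenyl and 4-methoxyphenyl groups differ in their heavy atoms and hydrogen-bond acceptors. The step of no change at the digits printed from compound 1 to compound 4 (within the scatter) adds a narrower comparison, methoxy in place of methyl on an aromatic carbon, so compounds 1, 2 and 4 now carry three different aryl groups at this place and this assay at its one dose does not separate them. Nothing at hand accounts for this sameness.

Going by these compounds, it remains open how far the aryl group can be changed at this place before the number falls, for instance with a carboxylic acid or an amine on the ring, and whether compounds 1, 2 and 4 would still match at lower doses. Compound 3 differs from compound 2 in more than one place, so its much lower number cannot be tied to any single change.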